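A few compounds are considered here, and "the series" means these few. Any claim that something is new, unique, unknown or untested is made for them only; others in the source may bear on it.

Compound 1 `CC(O)(CSc1ccc(C(F)(F)F)cc1)C(=O)Nc1cccc(S(F)(F)(F)(F)F)c1` gives in a functional assay on VCaP cells (Homo sapiens) for antiproliferative activity, read by propidium iodide staining, with a stated time of 96 h (a lower number here means a stronger inhibitor, a higher number a weaker inhibitor), a value of 27300 nM. Compound 2 `CC(O)(CSc1cccc(C(F)(F)F)c1)C(=O)Nc1cccc(S(F)(F)(F)(F)F)c1` gives 20200 nM in this assay, and compound 3 `CC(O)(CSc1ccc(OC(F)(F)F)cc1)C(=O)Nc1cccc(S(F)(F)(F)(F)F)c1` gives 28500 nM. The cores of compound 1 and compound 2 differ by 3-(trifluoromethyl)phenyl in place of 4-(trifluoromethyl)phenyl on a sulfur, a step of a 1.4-fold lower number from compound 1 to compound 2 (0.13 log units; within the scatter). From compound 1 to compound 3 the change is trifluoromethoxy in place of trifluoromethyl on an aromatic carbon, with a step of a 1.0-fold higher number from compound 1 to compound 3 (0.02 log units; within the scatter). Compound 4 `CC(O)(CSc1cccc(OC(F)(F)F)c1)C(=O)Nc1cccc(S(F)(F)(F)(F)F)c1` is not yet measured; it differs from compound 2 by trifluoromethoxy in place of trifluoromethyl on an aromatic carbon, the same kind of change as that from compound 1 to compound 3, which appears in two pairs here, the group standing para to a large group in compound 3 but meta to a large group in compound 4. Because the step of a 1.0-fold higher number from compound 1 to compound 3 (0.02 log units; within the scatter) lies within the scatter, the expected step from compound 2 to compound 4 in this assay is a 1.0-fold higher number from compound 2 to compound 4 (0.02 log units; within the scatter). Compound 4 is therefore estimated at 21000 nM, with the expected range 10000 nM to 42000 nM.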

Compound 4, half-maximal inhibitory concentration: 17500 nM
Compound 4: the middle estimate sits 1.2-fold (0.08 log units) above what was measured; low and high end bracket the measured number.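

In this assay, trifluoromethoxy in place of trifluoromethyl gives a 1.2-fold lower number from compound 2 to compound 4 (0.06 log units; within the scatter), and the two cores show no detectable difference in this change: the same change on two cores in this assay, a 1.0-fold higher number (0.02 log units; within the scatter) from compound 1 to compound 3 and a 1.2-fold lower number (0.06 log units; within the scatter) from compound 2 to compound 4, 1.2-fold (0.08 log units) apart, within the scatter of two such steps. Among these compounds, both steps lie within the scatter, so the notes can say only that the change leaves the number unresolved from its starting value on these two cores, whichever of the two placings on the ring is used. Among the compounds shown here, this does not show that the change would carry to a core differing elsewhere, nor does it show that a larger step would transfer, since no step of measurable size has been tested.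

Still open, as far as these compounds go, is how a nitrile, an amine or a carboxylic acid in place of these two groups would read in this assay. Also open, from the compounds shown here alone, is the effect of a longer chain between the sulfur and the ring.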